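Adding a fluoro to the benzyl of compound 3

The source may hold more compounds than are shown below. What is called first, only, known or untested is meant among the compounds shown, and "the series" means these compounds.

Measured so far in a functional assay on A2780 cells (Homo sapiens) for antiproliferative activity, read by resazurin assay, with a stated time of 72 h; a lower number here means a stronger inhibitor, a higher number a weaker inhibitor
compound 1 `Cc1ccccc1Cc1n[nH]c2cc(O)c(C(=O)N(C)Cc3ccccc3)cc12` gives "not determined" (no result reported)
compound 2 `CN(Cc1ccc(F)cc1)C(=O)c1cc2c(Cc3cccc(Cl)c3)n[nH]c2cc1O` gives 410 nM
compound 3 `Cc1cccc(Cc2n[nH]c3cc(O)c(C(=O)N(C)Cc4ccccc4)cc23)c1` gives 490 nM

In this assay compound 3 lies within the usual scatter of compound 2, and compound 1 offers no number for comparison. Compound 4 `Cc1cccc(Cc2n[nH]c3cc(O)c(C(=O)N(C)Cc4ccc(F)cc4)cc23)c1` departs from compound 3 in one place, where benzyl becomes 4-fluorobenzyl fluoro in place of hydrogen on an aromatic carbon with fluoro in place of hydrogen on an aromatic carbon. Among the compounds with values here, no two measured compounds differ in just one place, so this change has no direct precedent. Compound 2 also carries a 4-fluorobenzyl group and gives 410 nM in a similar range. The step of a 1.1-fold lower number from compound 3 to compound 4 (0.04 log units; within the scatter) is therefore expected to stay within the scatter, in no clear direction. For compound 4 the estimated value is 450 nM with an expected range from 200 nM to 1000 nM in this measurement.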

Compound 4, half-maximal inhibitory concentration: 590 nM
The estimate for compound 4 lay 1.3-fold (0.12 log units) below the measured number, within the range that was stated.
By their numbers in this assay, from the lowest: compounds 2, 3 and 4 (each within the scatter of the next).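

In this assay, fluoro in place of hydrogen on this aromatic carbon gives a 1.2-fold higher number from compound 3 to compound 4 (0.08 log units; within the scatter) and so shows that this position accepts the atom with no readable shift. A second single change, methyl in place of chloro on an aromatic carbon, gives a 1.4-fold higher number from compound 2 to compound 4 (0.16 log units; within the scatter) and likewise cannot be told apart from repeat measurements. Nothing here explains why the numbers stay so close. From the compounds shown here alone, whether a methoxy group, an amine or a carboxylic acid on this same carbon would leave the number equally unmoved remains open.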